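The compounds below may be only part of what the source reports. "The series", "measured", "known", "first", "only" and "open" are said of these compounds alone.

Working notes on the series. Compound 1 `O=C(Nc1ccc(Oc2ccnc3[nH]ccc23)c(F)c1)c1cc2cccnc2n(-c2ccc(C(F)(F)F)cc2Cl)c1=O` has no result in a functional assay on NCI-H460 cells (Homo sapiens) for antiproliferative activity, read by MTT assay, with a stated time of 72 h (on this read-out higher numbers stand for weaker inhibition and lower numbers for stronger inhibition), where compound 1 is recorded as "not determined" (no result reported). Compound 2 `Cn1ccc2c(Oc3ccc(NC(=O)c4cc5cccnc5n(-c5ccc(C(F)(F)F)cc5Cl)c4=O)cc3)ccnc21` gives 6950 nM in this assay. Compound 3 `COc1ccc(-n2c(=O)c(C(=O)Nc3ccc(Oc4ccnc5c4ccn5C)c(F)c3)cc3cccnc32)cc1` likewise carries no number; in this assay compound 3 stands at "not determined" (no result reported), so it offers no anchor of its own. Compound 4 `Cn1ccc2c(Oc3ccc(NC(=O)c4cc5cccnc5n(-c5ccc(C(F)(F)F)cc5Cl)c4=O)cc3F)ccnc21` is still to be measured. It differs from compound 3 by 2-chloro-4-(trifluoromethyl)phenyl in place of 4-methoxyphenyl on an aromatic nitrogen. Among the compounds with values here, no measured step covers this change, so its size and direction cannot be read from the series; the only neighbouring number is that of compound 2, which shares the entering group. Compound 4 is therefore expected to land near 5000 nM in this assay, with a range of 1500 nM to 20000 nM.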

Compound 4, half-maximal inhibitory concentration: 6010 nM
Beside the measured number, compound 4's estimate is 1.2-fold (0.08 log units) below it, and the stated range covers the measured number.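

In this assay, within the data shown here, the series gives its only readable step as a 1.2-fold lower number from compound 2 to compound 4 (0.06 log units; within the scatter) with 2-chloro-4-(trifluoromethyl)phenyl on the aromatic nitrogen in both compounds, so fluoro in place of hydrogen on an aromatic carbon does not move the number beyond the scatter here. The change from 4-methoxyphenyl to 2-chloro-4-(trifluoromethyl)phenyl cannot be read, as compound 3 carries no number. No measurement on hand bears on a cause for this result. Going by these compounds, how an amine or a longer alkyl chain on that aromatic nitrogen would read remains open.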